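This account rests on a few compounds, and the source may have more. Where it says the series, first, only, none or still open, it means among the compounds named here.

Compound 1 `COc1ccccc1Nc1nc(SCc2ccc(C(F)(F)F)cc2)nc2ccccc12`: in a functional assay on MGC-803 cells (Homo sapiens) for cytotoxicity, read by MTT assay, with a stated time of 72 h (on this read-out lower numbers stand for stronger inhibition and higher numbers for weaker inhibition), compound 1 gives > 50000 nM, which is a limit of the assay and not a number.
Compound 2 `FC(F)(F)c1ccc(CSc2nc(Nc3ccc(Cl)cc3)c3ccccc3n2)cc1`: in this assay compound 2 gives 16800 nM.

Compound 2 holds the only number shown; the other value is a limit (the limit of > 50000 nM in this assay, at which 1 of the 2 values shown sits). Compound 3 `COc1cc(Nc2nc(SCc3ccc(C(F)(F)F)cc3)nc3ccccc23)cc(OC)c1` differs from compound 2 in one place: 3,5-dimethoxyphenyl in place of 4-chlorophenyl on a nitrogen on an aromatic ring. Going by the values given here, only one measured step touches this position, the move from 2-methoxyphenyl to 4-chlorophenyl, which gave an at least 2.9-fold lower number from compound 1 to compound 2 (0.47 log units; beyond the scatter). That step runs in the opposite sense to the present one: compound 3 again carries methoxy groups on this ring, though not the same group as compound 1, and the data hold no comparison between the two. The expectation is therefore a step in this assay back toward a weaker number, roughly a 1.8-fold higher number from compound 2 to compound 3 (0.25 log units; within the scatter). Compound 3 is estimated at 30000 nM, with a range from 10000 nM to 90000 nM.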

Compound 3, half-maximal inhibitory concentration: 8580 nM
The estimate for compound 3 lay 3.5-fold (0.54 log units) above the measured number, and the stated range ends above it.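

In this assay the change from 4-chlorophenyl to 3,5-dimethoxyphenyl gives a 2.0-fold lower number from compound 2 to compound 3 (0.29 log units; within the scatter) and so leaves the two groups on this nitrogen indistinguishable, even though their rings carry different substituents. The other comparison is clearer: an at least 5.8-fold lower number from compound 1 to compound 3 (0.76 log units; beyond the scatter) shows that methoxy groups on this ring do not by themselves go with the weak result of compound 1. Compound 1 stands at a limit of the assay and not at a number, so the full size of that step stays unknown: the limit of > 50000 nM in this assay, at which 1 of the 3 values shown sits.

The compounds shown do not separate the number of methoxy groups on the ring from the places where they sit. They also leave open how this position would respond to a carboxylic acid or an amine on the ring, or to a simple alkyl chain in place of the ring.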